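The source may hold more compounds than are shown below. What is called first, only, known or untested is meant among the compounds shown, and "the series" means these compounds.

Compound 1 `C/C(=C\CC/C(C)=C/CC[C@@H]1[C@@]2(C)CCC(=O)C(C)(C)[C@H]2CC[C@@]1(C)O)CC/C=C(\C)C(=O)OCc1cn(-c2cccc(O)c2)nn1` carries a 1-(3-hydroxyphenyl)-1H-1,2,3-triazol-4-yl group on its ester, and in a functional assay on DU-145 cells (Homo sapiens) for antiproliferative activity, read by MTT assay, with a stated time of 48 h (on this read-out higher numbers stand for weaker inhibition and lower numbers for stronger inhibition), compound 1 gives 28400 nM, the lowest of the two numbers reported here. Compound 3 `C/C(=C\CC/C(C)=C/CC[C@@H]1[C@@]2(C)CCC(=O)C(C)(C)[C@H]2CC[C@@]1(C)O)CC/C=C(\C)C(=O)OCc1cn(-c2ccccc2)nn1`, with hydrogen in place of hydroxy on an aromatic carbon, gives 95500 nM in this assay, a step of a 3.4-fold higher number from compound 1 to compound 3 (0.53 log units; beyond the scatter). Compound 2 `C/C(=C\CC/C(C)=C/CC[C@@H]1[C@@]2(C)CCC(=O)C(C)(C)[C@H]2CC[C@@]1(C)O)CC/C=C(\C)C(=O)OCc1cn(-c2ccccc2C)nn1`, with 2-methylphenyl in place of 3-hydroxyphenyl on an aromatic nitrogen, reaches only a limit of this assay, > 150000 nM. That change reads as an at least 5.2-fold higher number from compound 1 to compound 2 (0.72 log units; beyond the scatter), while the comparison of compound 2 with compound 3 reads as an at least 1.5-fold lower number from compound 2 to compound 3 (0.19 log units; that floor lies within the scatter). Compound 4 `C/C(=C\CC/C(C)=C/CC[C@@H]1[C@@]2(C)CCC(=O)C(C)(C)[C@H]2CC[C@@]1(C)O)CC/C=C(\C)C(=O)OCc1cn(-c2cccc(F)c2)nn1` differs from compound 1 by fluoro in place of hydroxy on an aromatic carbon. Going by the values given here, the step that bears most directly on this change is the one to compound 3, where the loss of hydroxy raised the number modestly; fluoro likewise brings no hydrogen-bond donor or acceptor, and a rise of similar or somewhat smaller size is therefore expected, as a 2.1-fold higher number from compound 1 to compound 4 (0.32 log units; beyond the scatter). Compound 4 is estimated at 60000 nM, with a range from 25000 nM to 150000 nM.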

Compound 4, half-maximal inhibitory concentration: > 150000 nM
Compound 4 was reported as a limit; the forecaster's own chance of this, stated with the estimate: 15%; at least 2.5-fold (0.39 log units) between middle value and limit.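

In this assay, fluoro in place of hydroxy gives an at least 5.2-fold higher number from compound 1 to compound 4 (0.72 log units; beyond the scatter), so among these compounds the low number goes with the hydroxy, and not with just any substituent on this aromatic carbon. Against the unsubstituted phenyl of compound 3, fluoro shows an at least 1.5-fold higher number from compound 3 to compound 4 (0.19 log units; that floor lies within the scatter); that floor lies within the scatter, so this comparison does not show that fluoro does worse than hydrogen here. The step between compound 2 and compound 4 cannot be read, as both are limits and not numbers: the limit of > 150000 nM in this assay, at which 2 of the 4 values shown sit.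

Going by these compounds, whether an amine or a methoxy on this same aromatic carbon would stay close to compound 1 or fall in with compound 4 remains open. The compounds shown also leave open whether a carboxylic acid there would lower the number further than the hydroxy does.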